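Aryl variation on the ring amine nitrogen

This account rests on a few compounds, and the source may have more. Where it says the series, first, only, none or still open, it means among the compounds named here.

Measured so far:
compound 1 `Nc1scc(CN2CCN(c3ccc(F)cc3Cl)CC2)c1C(=O)c1ccc(Cl)cc1` — -6.2%
compound 2 `Nc1scc(CN2CCN(c3ccc(F)c(F)c3)CC2)c1C(=O)c1ccc(Cl)cc1` — -34%

In a functional assay on CHO cells with adenosine receptor A1 (Homo sapiens) as the target, read by cAMP accumulation and immunoassay, with a stated time of 6 min, tested at 0.1 uM (on this read-out higher numbers stand for a weaker effect at the one concentration tested and lower numbers for a stronger effect), compound 2 gives -34%, the lowest of the two numbers. Compound 1 gives -6.2%. Among the compounds with values here, the only step bearing on this position is a number 27.8 percentage points lower from compound 1 to compound 2 (beyond the scatter), a modest shift on exchanging the aryl group.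

Compound 3 `Nc1scc(CN2CCN(c3cc(Cl)ccc3Cl)CC2)c1C(=O)c1ccc(Cl)cc1` differs from compound 2 by 2,5-dichlorophenyl in place of 3,4-difluorophenyl on an amine nitrogen in a ring. One aryl exchange measured so far moved the read-out modestly; compound 1, which also carries chlorine on that ring, sits higher than compound 2. A step of comparable size is therefore expected, toward a weaker effect, a number 19 percentage points higher from compound 2 to compound 3 (beyond the scatter). Compound 3 is expected near -15%, between -40% and 10%.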

Compound 3, a percentage reported as activity, at one concentration (the size of the read-out at that concentration, not a potency): -6.2%
For compound 3 the middle estimate is 8.8 percentage points below the measured one; the range from low to high includes it.
By their numbers in this assay, from the lowest: compound 2; then compounds 1 and 3 (each within the scatter of the next).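

In this assay the exchange gives a number 27.8 percentage points higher from compound 2 to compound 3 (beyond the scatter) and also no change at the digits printed from compound 1 to compound 3 (within the scatter). Two aryl groups that both carry chlorine, 2,5-dichlorophenyl and 2-chloro-4-fluorophenyl, thus read alike on this amine nitrogen, and the 3,4-difluorophenyl of compound 2 stands apart from both. Nothing available explains this separation.

Compound 2 differs from compound 3 in both halogen and substitution pattern, so the two remain unseparated here. Also open, from the compounds shown here alone, is how an unsubstituted phenyl, a methoxyphenyl or a pyridyl group would read at this position.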